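Branching the ester: from propanoyl to tert-butyl carbonyl

The source may report more compounds than this note shows. Statements on the series, on what has been measured and on what is new or still open speak of the compounds shown alone.

Compound 1 `CCC(=O)OC1C(C(O)CO)OC2OC(C)(C)OC21` gives 2400000 nM in a functional assay on K562 cells (Homo sapiens) for inhibition; on this read-out lower numbers stand for stronger inhibition and higher numbers for weaker inhibition.
Compound 2 `CCCCCC(=O)OC1C(C(O)CO)OC2OC(C)(C)OC21` gives 1200000 nM in this assay.
Compound 3 `CC1(C)OC2OC(C(O)CO)C(OC(=O)CC(c3ccccc3)c3ccccc3)C2O1` gives 500000 nM in this assay.

Among these three numbers compound 1 stands highest, which here means the weakest inhibition. Compound 2 lies nearest, a step that stays within the scatter, and compound 3 lies furthest, beyond the scatter. Compound 4 `CC1(C)OC2OC(C(O)CO)C(OC(=O)C(C)(C)C)C2O1` has not yet been measured. It differs from compound 1 in one place: tert-butyl in place of ethyl on a carbonyl carbon.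

Within the data shown here, the only measured step that bears on this change is the one that also lengthens the ester chain of compound 1: a 2.0-fold lower number from compound 1 to compound 2 (0.30 log units; within the scatter). That step gave a lower number, yet one inside the scatter. Compound 3 carries a still larger ester and shows a lower number than compound 1, but no single-step comparison links those two. The change in compound 4 is a smaller addition than either, so little or no movement beyond the scatter is expected, perhaps a slight drift towards lower numbers.

Compound 4 is therefore estimated at 1600000 nM, within 600000 nM to 4500000 nM, which means an expected step of a 1.5-fold lower number from compound 1 to compound 4 (0.18 log units; within the scatter).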

Compound 4, half-maximal inhibitory concentration: 1500000 nM
Beside the measured number, compound 4's estimate is 1.1-fold (0.03 log units) above it, and the stated range covers the measured number.
By their numbers in this assay, from the lowest: compound 3; then compounds 2, 4 and 1 (each within the scatter of the next).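

Replacing ethyl with tert-butyl on a carbonyl carbon gives a 1.6-fold lower number from compound 1 to compound 4 (0.20 log units; within the scatter) in this assay, so a branched group with 4 heavy atoms in place of 2 leaves the number inside the scatter at this position. Against the unbranched pentyl group, the result is a 1.3-fold higher number from compound 2 to compound 4 (0.10 log units; within the scatter), which means that branched and straight groups on this carbonyl carbon cannot be told apart on this read-out. Nothing measured here offers an explanation for these small steps.

Going by these compounds, it remains open whether an amine, a carboxylic acid or a chain longer than pentyl in this place would move the number beyond the scatter. On these data alone, all of these numbers also come from this assay alone, so whether the same small steps would appear on another read-out is unknown.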